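Growth of the Group on the Aromatic Nitrogen of the Shared Core: Phenyl for Ethyl

The source may report more compounds than this note shows. Statements on the series, on what has been measured and on what is new or still open speak of the compounds shown alone.

Compound 2 `CCOC(=O)c1cc(-c2cccc(OC(=O)NC3CCCCC3)c2)nn1CC` carries an ethyl on the aromatic nitrogen of the shared core; in an assay on isolated protein for inhibition of Fatty-acid amide hydrolase 1 (Homo sapiens), read by fluorescence, with a stated time of 30 min (a higher number here means a weaker inhibitor, a lower number a stronger inhibitor), compound 2 gives 507 nM, the highest of the two numbers in hand. Its nearest neighbour is compound 1 `CCOC(=O)c1cc(-c2cccc(OC(=O)NC3CCCCC3)c2)nn1C`, which in this assay gives 227 nM. Going by the values given here, the one measured change on that nitrogen is a 2.2-fold higher number from compound 1 to compound 2 (0.35 log units; beyond the scatter), a modest weakening as the group grows from methyl to ethyl.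

Compound 3 `CCOC(=O)c1cc(-c2cccc(OC(=O)NC3CCCCC3)c2)nn1-c1ccccc1` is not yet measured. It differs from compound 2 by phenyl in place of ethyl on an aromatic nitrogen. Among the compounds with values here, only the methyl-to-ethyl step bears on this change, and it points towards a weaker number as the group on the aromatic nitrogen grows; no measured pair shows whether a phenyl follows the same line, so the range is kept wide. The expected step is a 2.0-fold higher number from compound 2 to compound 3 (0.29 log units; within the scatter). Compound 3 is thus expected to give 1000 nM in this assay, with a range of 300 nM to 4000 nM.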

Compound 3, half-maximal inhibitory concentration: 539 nM
Compound 3: the middle estimate sits 1.9-fold (0.27 log units) above what was measured, within the range that was stated.
By their numbers in this assay, from the lowest: compound 1; then compounds 2 and 3 (each within the scatter of the next).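

In this assay the exchange of ethyl for phenyl on the aromatic nitrogen reads as a 1.1-fold higher number from compound 2 to compound 3 (0.03 log units; within the scatter) and so leaves compounds 2 and 3 indistinguishable, which shows that the weakening from methyl to ethyl does not continue with this larger group bearing an aromatic ring. Measured against the methyl group, the phenyl reads as a 2.4-fold higher number from compound 1 to compound 3 (0.38 log units; beyond the scatter) and stays a modest step, so on the three compounds shown methyl alone stands apart from the other two groups. Nothing available here accounts for ethyl and phenyl reading alike.

Open, as far as these compounds go, is whether a longer chain such as propyl, or a benzyl, would match ethyl and phenyl on this nitrogen. Also open, from the compounds shown here alone, is how a phenyl carrying a methoxy or an amine would read, and how a plain hydrogen there would compare with methyl.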